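The compounds below may be only part of what the source reports. "The series", "measured", "known", "first", "only" and "open" are said of these compounds alone.

Measured so far:

Compound 1, `O=C(N/N=C/c1c[nH]c2ccccc12)c1ccc(CSc2nc3ccccc3s2)cc1`, gives in a functional assay on BCG823 cells (Homo sapiens) for inhibition, read by MTT assay, with a stated time of 72 h (a higher number here means a weaker inhibitor, a lower number a stronger inhibitor), only a limit of the assay, namely > 80 ug/mL.
Compound 2, `COc1cc(/C=N/NC(=O)c2ccc(CSc3nc4ccccc4s3)cc2)cc(OC)c1OC`, likewise gives in this assay only a limit of the assay, > 80 ug/mL.
Compound 3, `COc1cc(/C=N/NC(=O)c2ccc(CSc3nc(C)cc(C)n3)cc2)cc(OC)c1OC`, gives in this assay a number, 36.8 ug/mL.

Compound 2 and compound 3 share a core and differ in one place: 4,6-dimethylpyrimidin-2-yl in place of 1,3-benzothiazol-2-yl on a sulfur. That change produced the step of an at least 2.1-fold lower number from compound 2 to compound 3 (0.33 log units; beyond the scatter). Its size can be stated only as a floor because of the limit of > 80 ug/mL in this assay, at which 2 of the 3 values shown sit; the true step may be larger.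

Compound 1 and compound 2 carry different cores, and the difference between the two cores is not broken down here. Compound 4, `Cc1cc(C)nc(SCc2ccc(C(=O)N/N=C/c3c[nH]c4ccccc34)cc2)n1`, still unmeasured, stands to compound 1 exactly as compound 3 stands to compound 2: 4,6-dimethylpyrimidin-2-yl in place of 1,3-benzothiazol-2-yl on a sulfur. The place of the change is described in the same words for both pairs, so it is the same change made on a different core.

The expectation for compound 4 rests on a single measured example. On the core of compound 2 the change brought a weak inhibitor into the measurable range, and the same behaviour is expected here, so the step of an at least 1.7-fold lower number from compound 1 to compound 4 (0.24 log units; that floor lies within the scatter) is estimated to be of similar size. Going by the values given here, compound 4 is therefore expected to give in this assay about 45 ug/mL, with a plausible range from 18 ug/mL to 80 ug/mL, though the possibility that it again falls outside the measurable range remains real given that only one such step has been seen.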

Compound 4, half-maximal inhibitory concentration: 35.5 ug/mL
Beside the measured number, compound 4's estimate is 1.3-fold (0.10 log units) above it, and the stated range covers the measured number.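

On the core of compound 1, putting 4,6-dimethylpyrimidin-2-yl in place of 1,3-benzothiazol-2-yl on a sulfur gave in this assay an at least 2.2-fold lower number from compound 1 to compound 4 (0.35 log units; beyond the scatter), so the change lowered the number on both cores shown, and in each case the step lies beyond the scatter. This shows that the direction of the change carried over from one core to the other, but two cores are a small sample, and whether the size carried over as well stays unsettled: the same change on two cores in this assay, an at least 2.1-fold lower number (0.33 log units; beyond the scatter) from compound 2 to compound 3 and an at least 2.2-fold lower number (0.35 log units; beyond the scatter) from compound 1 to compound 4; the limit leaves it open whether they differ Each step can be given only as a floor, and its true size stays hidden, because the starting compound of each pair gave only a limit of the assay rather than a number: the limit of > 80 ug/mL in this assay, at which 2 of the 4 values shown sit.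

The compounds shown leave open whether the same change would lower the number on a third core, and whether the two methyl groups of the 4,6-dimethylpyrimidin-2-yl group contribute to the step at all. They also leave open how other groups on the sulfur would compare, such as an unsubstituted pyrimidin-2-yl, a pyridin-2-yl or a plain saturated chain ending in an amine.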